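Removing an Acetyl Group on Two Related Cores

The source may hold more compounds than are shown below. What is called first, only, known or untested is meant among the compounds shown, and "the series" means these compounds.

Three compounds have been measured in an ADME assay on THP-1 cells (Homo sapiens) for cytotoxicity, read by flow cytometry and propidium iodide staining, with a stated time of 72 h; on this read-out higher numbers stand for weaker inhibition and lower numbers for stronger inhibition:
compound 1 `COc1ccc(-c2cc(=O)c3cc(NC(C)=O)ccc3o2)cc1` gives 74000 nM;
compound 2 `COc1ccc(-c2cc(=O)c3cc(N)ccc3o2)cc1` gives 124000 nM;
compound 3 `CC(=O)Nc1ccc2oc(-c3ccccc3)c(O)c(=O)c2c1` gives 36000 nM.

Compound 1 and compound 2 share one core and differ in a single place: hydrogen in place of acetyl on a nitrogen on an aromatic ring. This change produced a 1.7-fold higher number from compound 1 to compound 2 (0.22 log units; within the scatter), so the two numbers cannot be told apart with confidence. Compound 3 is built on a different core; how its core differs from the core of compound 1 is not broken down here. In this assay compound 3 gives the lowest of the three numbers, and its gap to compound 1 as well as to compound 2 lies beyond the scatter.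

Compound 4 `Nc1ccc2oc(-c3ccccc3)c(O)c(=O)c2c1` has not yet been measured. It stands to compound 3 as compound 2 stands to compound 1: hydrogen in place of acetyl on a nitrogen on an aromatic ring. The surroundings of the changed position are described in the same words for both pairs, so this is the same change carried over to a different core. For the measured compounds named here, the only guide to its effect is the earlier pair, where the number moved little. Because a 1.7-fold higher number from compound 1 to compound 2 (0.22 log units; within the scatter) a step of similar size and direction is expected here, namely a 1.7-fold higher number from compound 3 to compound 4 (0.22 log units; within the scatter). Compound 4 is therefore estimated at 60000 nM in this assay, with a likely range from 25000 nM to 150000 nM.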

Compound 4, half-maximal inhibitory concentration: 27000 nM
The estimate for compound 4 lay 2.2-fold (0.35 log units) above the measured number; measured number inside the range.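

On the second core, the change from acetamido to amino gave a 1.3-fold lower number from compound 3 to compound 4 (0.12 log units; within the scatter) in this assay, a step too small to separate from the ordinary spread of repeated measurements. Set beside the earlier pair, the step on this core cannot be distinguished from the one on the first core, so in both cases the change leaves the two numbers indistinguishable: the same change on two cores in this assay, a 1.7-fold higher number (0.22 log units; within the scatter) from compound 1 to compound 2 and a 1.3-fold lower number (0.12 log units; within the scatter) from compound 3 to compound 4, 2.2-fold (0.35 log units) apart, within the scatter of two such steps. This shows that swapping acetyl for hydrogen on this nitrogen had no clear effect on either of these two cores, but it does not show a real reversal of direction between them, since each step is too small for its direction to be trusted, and two pairs cannot establish a rule for the whole series.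

The compounds shown keep to only two options on this nitrogen, acetyl and hydrogen, so it remains open whether a longer acyl chain such as butanoyl, or a methanesulfonyl group, would move the number beyond the scatter. As far as these compounds go, it also remains open whether the same change would behave alike on a third core or in any other assay.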